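A few compounds are considered here, and "the series" means these few. Any claim that something is new, unique, unknown or untested is made for them only; others in the source may bear on it.

Measured so far:
Compound 1 `Nc1ccc(F)cc1NC(=O)c1ccc(CNC(=O)/C=C/c2cnc3cccnn23)cc1`: 812 nM
Compound 2 `Nc1ccccc1NC(=O)c1ccc(CNC(=O)/C=C/c2cnc3cccnn23)cc1`: 723 nM

In a functional assay on A549 cells (Homo sapiens) for inhibition, read by MTT assay, with a stated time of 72 h (a lower number here means a stronger inhibitor, a higher number a weaker inhibitor), compound 2 gives 723 nM, level with compound 1 within the scatter. Compound 3 `Nc1cc(F)ccc1NC(=O)c1ccc(CNC(=O)/C=C/c2cnc3cccnn23)cc1` carries fluoro in place of hydrogen on an aromatic carbon, para to a large group: fluoro in place of hydrogen on an aromatic carbon. Within the data shown here, the one measured step that bears on this is a 1.1-fold lower number from compound 1 to compound 2 (0.05 log units; within the scatter). It swaps the same two substituents, though at a different place on the ring, and it stays within the scatter. No change beyond the scatter is therefore expected in this assay. The expected step is a 1.0-fold higher number from compound 2 to compound 3 (0.02 log units; within the scatter). For compound 3 the estimated value is 750 nM, with an expected range of 350 nM to 1600 nM.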

Compound 3, half-maximal inhibitory concentration: 791 nM
For compound 3 the middle estimate is 1.1-fold (0.02 log units) below the measured one; low and high end bracket the measured number.
By their numbers in this assay, from the lowest: compounds 2, 3 and 1 (each within the scatter of the next).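

In this assay the fluoro para to a large group gives a 1.1-fold higher number from compound 2 to compound 3 (0.04 log units; within the scatter) and shifting the fluoro from the 2-amino-5-fluorophenyl to the 2-amino-4-fluorophenyl arrangement gives a 1.0-fold lower number from compound 1 to compound 3 (0.01 log units; within the scatter). Both steps stay within the scatter, so this small atom is now tolerated at two ring places, with neither place set apart from the other or from the ring without fluoro. Nothing available explains this result. From the compounds shown here alone, whether chloro or methoxy at this same carbon would move the number beyond the scatter stays open.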